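This account rests on a few compounds, and the source may have more. Where it says the series, first, only, none or still open, it means among the compounds named here.

Among the compounds with values here, compound 3 `CCC[C@@H](CO)Nc1nc(N)nc(C)c1Cc1ccc(CNCCO)cc1OC` is the one compound of the three with a number in an assay on HEK293 cells for agonist activity at Toll-like receptor 8 (Homo sapiens); on this read-out higher numbers stand for an effect only at larger amounts of compound and lower numbers for an effect already at smaller amounts: compound 3 gives 5370 nM. Compound 1 `CCC[C@@H](CCO)Nc1nc(N)nc(C)c1Cc1ccc(CN(C)CC(N)=O)cc1OC` reaches only the limit of this assay, > 10000 nM. Compound 2 `CCC[C@@H](CCO)Nc1nc(N)nc(C)c1Cc1ccc(CNC2CNC2)cc1OC` likewise reaches only the limit, > 10000 nM. The step from compound 1 to compound 2 is a step that the two limits leave unreadable from compound 1 to compound 2, its size hidden because of the limit of > 10000 nM in this assay, at which 2 of the 3 values shown sit. Compound 4 `CCC[C@@H](CO)Nc1nc(N)nc(C)c1Cc1ccc(CNC)cc1OC` differs from compound 3 by hydrogen in place of hydroxymethyl on a saturated chain carbon bound to an amine nitrogen, that is, 2-hydroxyethyl to methyl on a saturated chain carbon bound to an amine nitrogen. Within the data shown here, no measured step touches that part of the molecule, so there is no guide for this change. Compound 4 is expected to give about 5000 nM, within a range of 1500 nM to 15000 nM. That step is expected to be a 1.1-fold lower number from compound 3 to compound 4 (0.03 log units; within the scatter), within the usual scatter.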

Compound 4, half-maximal effective concentration: 2140 nM
Compound 4: the middle estimate sits 2.3-fold (0.37 log units) above what was measured, and the stated range covers the measured number.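

In this assay, the change from 2-hydroxyethyl to methyl on a saturated chain carbon bound to an amine nitrogen gives a 2.5-fold lower number from compound 3 to compound 4 (0.40 log units; beyond the scatter). Within the data shown here, this is the first step with a readable size, and it shows that the hydroxymethyl is not needed for a measurable effect and that changing this group can move the number. The one earlier step could not be read: the limit of > 10000 nM in this assay, at which 2 of the 4 values shown sit.

Still open, as far as these compounds go, is how a plain primary amine or an ethylamino group would read here. Also open, from the compounds shown here alone, is whether a longer carbon chain on the nitrogen would lower the number further.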